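The compounds below may be only part of what the source reports. "The series", "measured", "known", "first", "only" and "open" are said of these compounds alone.

Compound 1, `O=C(N/N=C/c1cc(I)cc(I)c1O)c1ccccc1` — in a functional assay on HepG2 cells (Homo sapiens) for cytotoxicity, with a stated time of 24 h (on this read-out higher numbers stand for weaker inhibition and lower numbers for stronger inhibition), compound 1 gives > 50000 nM, which is a limit of the assay and not a number.
Compound 2, `COc1ccc(C(=O)N/N=C/c2cc(I)cc(I)c2O)cc1` — in this assay compound 2 gives 45200 nM.

Compound 1 stands at the limit of > 50000 nM in this assay, at which 1 of the 2 values shown sits, so only a limit is known for it. For the measured compounds named here, the one measured step leads away from it: an at least 1.1-fold lower number from compound 1 to compound 2 (0.04 log units; that floor lies within the scatter), a change that stays within the scatter, so compound 1 and compound 2 show no difference that can be read as order. Compound 3, `O=C(N/N=C/c1cc(I)cc(I)c1O)c1ccc(I)cc1`, differs from compound 1 by iodo in place of hydrogen on an aromatic carbon. Going by the values given here, no measured step concerns an iodo entering this ring; the only measured change on the same ring, the one from compound 1 to compound 2, left the number within the scatter, and that is the only guide. The step is therefore expected to be small: an at least 1.2-fold lower number from compound 1 to compound 3 (0.09 log units; that floor lies within the scatter), with the chance that compound 3 again returns only a limit. Compound 3 is estimated at 40000 nM, within a range of 15000 nM to 50000 nM.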

Compound 3, half-maximal inhibitory concentration: 31800 nM
The estimate for compound 3 lay 1.3-fold (0.10 log units) above the measured number, and the stated range covers the measured number.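

With iodo as 4-iodophenyl in place of phenyl, compound 3 returns a measured number in this assay, so this position now has a second substituent with a number, and the step from the unsubstituted compound gains a second reading: an at least 1.5-fold lower number from compound 1 to compound 3 (0.19 log units; that floor lies within the scatter). From the compounds shown here alone, that step is only a floor, and its true size stays unknown, since compound 1 is a limit of the assay and not a number: the limit of > 50000 nM in this assay, at which 1 of the 3 values shown sits. The comparison of the two substituents para to a large group does rest on two numbers, and it gives a 1.4-fold lower number from compound 2 to compound 3 (0.15 log units; within the scatter), so iodo and methoxy at this place cannot be told apart in this read-out, although they differ in their atoms and in their heavy-atom count.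

The compounds shown therefore leave open whether any group at this position can move the number beyond the scatter, and how far compound 1 truly lies from compound 2 and compound 3. They also leave open what an amine, a carboxylic acid or a longer chain would do at this place on the shared core.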